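This account rests on a few compounds, and the source may have more. Where it says the series, first, only, none or still open, it means among the compounds named here.

In an ADME assay on HOS cells (Homo sapiens) for cytotoxicity (on this read-out higher numbers stand for lower toxicity in this test and lower numbers for higher toxicity in this test), compound 1 `CN(Cc1nc2ccccc2n1CCCCN)C1CCCc2cccnc21` gives 2900 nM and compound 2 `CN(C)CCCn1c(CN(C)C2CCCc3cccnc32)nc2ccccc21` gives 16800 nM. Compound 3 `CN(Cc1nc2ccccc2n1CCCNC(=N)N)C1CCCc2cccnc21` stands only at a limit of the assay, > 20000 nM. Compound 4 `CN(Cc1nc2ccccc2n1CCCNC(=O)C(F)(F)F)C1CCCc2cccnc21`, not yet measured, differs from compound 3 on an amine nitrogen: a group of 6 heavy atoms (2 carbon, 1 oxygen, 3 fluorine; no ring) in place of a group of 3 heavy atoms (1 carbon, 2 nitrogen; no ring), on an amine nitrogen. Three measured steps change the same chain end. Both a 5.8-fold higher number from compound 1 to compound 2 (0.76 log units; beyond the scatter) and an at least 6.8-fold higher number from compound 1 to compound 3 (0.83 log units; beyond the scatter) lie beyond the scatter, while the floor of an at least 1.1-fold higher number from compound 2 to compound 3 (0.07 log units; that floor lies within the scatter) lies within it. None of them introduces (trifluoromethyl)carbonyl, so they are only a loose guide. A modest move toward a lower number is therefore expected in this assay. The expected step is an at least 1.4-fold lower number from compound 3 to compound 4 (0.15 log units; that floor lies within the scatter). Compound 4 is estimated at 14000 nM, with an expected range of 5000 nM to 20000 nM.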

Compound 4, half-maximal cytotoxic concentration: 10400 nM
Beside the measured number, compound 4's estimate is 1.3-fold (0.13 log units) above it; the measured number falls inside the stated range.
By their numbers in this assay, from the lowest: compound 1; then compounds 4 and 2 (each within the scatter of the next). At a limit, above all of these: compound 3.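

In this assay, placing (trifluoromethyl)carbonyl on the amine nitrogen shows that a group with 0 hydrogen-bond donors also keeps the number clear of the primary amine end, with a 3.6-fold higher number from compound 1 to compound 4 (0.55 log units; beyond the scatter). Against the dimethylamino end there is a 1.6-fold lower number from compound 2 to compound 4 (0.21 log units; within the scatter), so these two chain ends cannot be told apart here. The step to the guanidine-bearing end is only a floor, an at least 1.9-fold lower number from compound 3 to compound 4 (0.28 log units; that floor lies within the scatter).

Its true size stays open because compound 3 sits at a limit of the assay: the limit of > 20000 nM in this assay, at which 1 of the 4 values shown sits.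
On these data alone, whether a carboxylic acid or a longer chain at this position would keep the number as high also remains open.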